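A few compounds are considered here, and "the series" means these few. Any claim that something is new, unique, unknown or untested is made for them only; others in the source may bear on it.

Compound 1 `NCCOCCOc1ccc([C@H]2CC[C@]3(CC2)OOC2(O3)C3CC4CC(C3)CC2C4)cc1` and compound 2 `N[C@H]1CC[C@H](Oc2ccc([C@H]3CC[C@]4(CC3)OOC3(O4)C4CC5CC(C4)CC3C5)cc2)CC1` share one core and differ only in the group on an oxygen on an aromatic ring. In an ADME assay on microsomes from liver (Homo sapiens) for metabolic stability, read by LC-MS, tested at 1 uM (a higher number here means faster removal of the compound, a lower number slower removal), compound 1 gives a value that is a limit of the assay, < 7 mL.min-1.g-1. Compound 2 also gives only a limit there, < 7 mL.min-1.g-1. The step that the two limits leave unreadable from compound 1 to compound 2 therefore cannot be sized, and both values sit at the limit of < 7 mL.min-1.g-1 in this assay, at which 2 of the 2 values shown sit. Compound 3 `c1cc([C@H]2CC[C@]3(CC2)OOC2(O3)C3CC4CC(C3)CC2C4)ccc1OC1CCNCC1` carries the change (piperidin-4-yl in place of 4-aminocyclohexyl on an oxygen on an aromatic ring). Among the compounds with values here, no measured step bears on this change, so compound 3 is expected to stay at the same limit, with an expected step that the limit leaves unreadable from compound 2 to compound 3. The estimate for compound 3 is 5 mL.min-1.g-1, between 2 mL.min-1.g-1 and 14 mL.min-1.g-1.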

Compound 3, intrinsic clearance in microsomes: 15 mL.min-1.g-1
For compound 3 the middle estimate is 3.0-fold (0.48 log units) below the measured one; the whole stated range lies below it.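

On an oxygen on an aromatic ring, the group turns out to matter in this assay: piperidin-4-yl in place of 4-aminocyclohexyl gives an at least 2.1-fold higher number from compound 2 to compound 3 (0.33 log units; beyond the scatter). Against the open-chain 2-(2-aminoethoxy)ethyl group, the same ring gives an at least 2.1-fold higher number from compound 1 to compound 3 (0.33 log units; beyond the scatter). Both steps are minimum sizes, and compound 3 alone has left the limit: the limit of < 7 mL.min-1.g-1 in this assay, at which 2 of the 3 values shown sit.

The compounds shown do not separate the ring with its nitrogen from the loss of the defined stereocentres. From the compounds shown here alone, whether 1-methylpiperidin-4-yl or pyrrolidin-3-yl on the same oxygen would resemble compound 3 or return to the limit also stays open.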